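The compounds below may be only part of what the source reports. "The series", "measured", "known", "first", "only" and "open" are said of these compounds alone.

In a functional assay on HT-29 cells (Homo sapiens) for inhibition, read by luminescence and CellTiter-Glo, with a stated time of 24 h (on this read-out higher numbers stand for an effect only at larger amounts of compound and lower numbers for an effect already at smaller amounts), three compounds that share one core and differ only in the group on an aromatic nitrogen have been measured. Compound 1 `CCCn1nc(C(=O)N[C@H]2COc3ccccc3N(C)C2=S)nc1Cc1ccccc1`, with propyl, gives 288 nM. Compound 2 `CC(C)CCn1nc(C(=O)N[C@H]2COc3ccccc3N(C)C2=S)nc1Cc1ccccc1`, with isopentyl, gives 3640 nM. Compound 3 `CN1C(=S)[C@@H](NC(=O)c2nc(Cc3ccccc3)n(C3CCCCCC3)n2)COc2ccccc21`, with cycloheptyl, gives 5530 nM.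

Compound 3 therefore sits at the high end of these numbers, level with compound 2 but far from compound 1: the measured steps are a 1.5-fold higher number from compound 2 to compound 3 (0.18 log units; within the scatter) and a 19-fold higher number from compound 1 to compound 3 (1.28 log units; beyond the scatter). The step of a 13-fold higher number from compound 1 to compound 2 (1.10 log units; beyond the scatter) is similarly large.

Compound 4 `CN1C(=S)[C@@H](NC(=O)c2nc(Cc3ccccc3)n(C3CCOCC3)n2)COc2ccccc21` has oxan-4-yl in place of cycloheptyl on an aromatic nitrogen. Among the measured compounds shown here, no measured compound carries oxan-4-yl, so no step measures this change directly. The steps from compound 1 show only that this nitrogen's group can move the number strongly.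

A modest move to a lower number is therefore expected in this assay, with the estimate being a 2.2-fold lower number from compound 3 to compound 4 (0.34 log units; beyond the scatter). For compound 4 the estimated value is 2500 nM, with an expected range from 600 nM to 9000 nM.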

Compound 4, half-maximal effective concentration: 2260 nM
Beside the measured number, compound 4's estimate is 1.1-fold (0.04 log units) above it; the measured number falls inside the stated range.
By their numbers in this assay, from the lowest: compound 1; then compounds 4, 2 and 3 (each within the scatter of the next, the first and the last beyond it).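

In this assay, replacing the seven-membered carbon ring of cycloheptyl with the six-membered oxygen-containing ring of oxan-4-yl gives a 2.4-fold lower number from compound 3 to compound 4 (0.39 log units; beyond the scatter), so a change within the ring at this nitrogen can shift the number modestly, even with a ring kept in place. The shift does not set oxan-4-yl apart from the open-chain isopentyl, with a 1.6-fold lower number from compound 2 to compound 4 (0.21 log units; within the scatter), and it leaves a clear gap to propyl, with a 7.8-fold higher number from compound 1 to compound 4 (0.89 log units; beyond the scatter), so among these groups propyl alone gives a markedly lower number. No measurement shown here accounts for these steps.

The step changes ring size and adds an oxygen at once, and cyclohexyl on the same nitrogen would separate the two. Also open, from the compounds shown here alone, is how ethyl, butyl or the amine-bearing piperidin-4-yl would compare with propyl and oxan-4-yl.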